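Fluoro in Place of Hydrogen: What to Expect for Compound 4

The compounds below may be only part of what the source reports. "The series", "measured", "known", "first", "only" and "open" are said of these compounds alone.

Compound 1 `COc1cc2nc(Nc3ccc(S(C)(=O)=O)cc3)nc(OCC3CCN(C(=O)OC(C)(C)C)CC3)c2cc1OC` and compound 2 `COc1cc2nc(Nc3ccc(S(C)(=O)=O)cc3F)nc(OCC3CCN(C(=O)OC(C)(C)C)CC3)c2cc1OC` share one core, while compound 3 `COc1cc2nc(N3CCC4CCC(C3)N4Cc3ccccc3)nc(Nc3ccc(S(C)(=O)=O)cc3)c2cc1OC` and the unmeasured compound 4 `COc1cc2nc(N3CCC4CCC(C3)N4Cc3ccccc3)nc(Nc3ccc(S(C)(=O)=O)cc3F)c2cc1OC` share another; the difference between the two cores is not broken down here. In a functional assay on HEK293 cells for agonist activity at Glucose-dependent insulinotropic receptor (Homo sapiens), read by cAMP accumulation, with a stated time of 60 min (a higher number here means that more compound is needed for the effect, a lower number that less compound is needed), compound 1 gives only a limit, > 10000 nM. Compound 2 likewise gives only a limit in this assay, > 10000 nM. Compound 3 also reaches only a limit in this assay, > 10000 nM. The change from compound 1 to compound 2 is fluoro in place of hydrogen on an aromatic carbon, and its step, a step that the two limits leave unreadable from compound 1 to compound 2, cannot be sized since both ends are limits (the limit of > 10000 nM in this assay, at which 3 of the 3 values shown sit). Compound 4 carries the same change, (fluoro in place of hydrogen on an aromatic carbon), at the same place. The expected step that the limit leaves unreadable from compound 3 to compound 4 is small because compound 3 already sits at the limit (the limit of > 10000 nM in this assay, at which 3 of the 3 values shown sit). Compound 4 is expected near 15000 nM, between 5000 nM and 50000 nM, most likely again reported only as a limit.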

Compound 4, half-maximal effective concentration: > 10000 nM
Compound 4 was reported as a limit; the forecaster's own chance of this, stated with the estimate: 85%; the middle value lies beyond the limit too.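

Compound 3 and compound 4 both end at a limit rather than a number, so no step can be read between them, because every value here sits there: the limit of > 10000 nM in this assay, at which 4 of the 4 values shown sit 

From the compounds shown here alone, whether fluoro in place of hydrogen changes the response at all in this assay stays open.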